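Amide substituent exchange on the chalcone amides: compound 3

The source may hold more compounds than are shown below. What is called first, only, known or untested is meant among the compounds shown, and "the series" means these compounds.

Measured so far:
compound 1 `COc1cc(/C=C/C(=O)c2cccc(NC(=O)c3ccco3)c2)ccc1O` — 5.46 ug/mL
compound 2 `COC(=O)C(=O)Nc1cccc(C(=O)/C=C/c2ccc(O)c(OC)c2)c1` — 4.41 ug/mL

In a functional assay on B16 cells (Mus musculus) for inhibition (on this read-out higher numbers stand for weaker inhibition and lower numbers for stronger inhibition), compound 1 gives 5.46 ug/mL, while compound 2 gives 4.41 ug/mL. Among the compounds with values here, the only measured step, a 1.2-fold lower number from compound 1 to compound 2 (0.09 log units; within the scatter), exchanges the group on the amide carbonyl carbon and stays within the scatter; compound 2 has the lower of the two numbers, but the two values are not separated beyond the scatter.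

Compound 3 `COc1cc(/C=C/C(=O)c2cccc(NC(=O)c3c(Cl)cccc3Cl)c2)ccc1O` differs from compound 2 by 2,6-dichlorophenyl in place of methoxycarbonyl on a carbonyl carbon. The step that bears on this is a 1.2-fold lower number from compound 1 to compound 2 (0.09 log units; within the scatter), which shows that exchanging the group on this carbonyl carbon left the read-out essentially unchanged. Within the data shown here, no measured step introduces 2,6-dichlorophenyl, so the direction is uncertain. On this basis no step beyond the scatter is expected in this assay, that is a 1.0-fold higher number from compound 2 to compound 3 (0.01 log units; within the scatter). Compound 3 is estimated at 4.5 ug/mL, with a range from 1.5 ug/mL to 13 ug/mL.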

Compound 3, half-maximal inhibitory concentration: 1.58 ug/mL
Estimate against measurement, compound 3: 2.8-fold (0.45 log units) above; low and high end bracket the measured number.
By their numbers in this assay, from the lowest: compound 3; then compounds 2 and 1 (each within the scatter of the next).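

In this assay the group on this carbonyl carbon now makes a difference: 2,6-dichlorophenyl in place of methoxycarbonyl gives a 2.8-fold lower number from compound 2 to compound 3 (0.45 log units; beyond the scatter) and in place of furan-2-yl gives a 3.5-fold lower number from compound 1 to compound 3 (0.54 log units; beyond the scatter), both modest steps towards stronger inhibition. Within the data shown here, the earlier exchange of furan-2-yl for methoxycarbonyl stayed within the scatter, so the position looked flat only across that pair, and 2,6-dichlorophenyl is the first group here to separate from the others. Nothing in hand accounts for this gain.

The compounds shown leave open whether the gain tracks the two chlorines or the aromatic ring itself, a question that unsubstituted phenyl or 2,6-dimethylphenyl on this carbonyl carbon would address. Also open, going by these compounds, is how an amine, such as dimethylaminomethyl, would read at the same place.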